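Adding a Methoxy Group to a Series at the Limit

A few compounds are considered here, and "the series" means these few. Any claim that something is new, unique, unknown or untested is made for them only; others in the source may bear on it.

Compound 1 `COc1ccc2oc(/C=C/c3ccc(OC(F)(F)F)cc3)cc(=O)c2c1` gives > 40000 nM in a functional assay on PC-3 cells (Homo sapiens) for antiproliferative activity, read by MTT assay, with a stated time of 12 h (a higher number here means a weaker inhibitor, a lower number a stronger inhibitor), which is a limit of the assay and not a number.
Compound 2 `COc1ccc2c(=O)cc(/C=C/c3ccc(OC(F)(F)F)cc3)oc2c1` gives > 40000 nM in this assay, again a limit.
Compound 3 `COc1cc(OC)c2c(=O)cc(/C=C/c3ccccc3)oc2c1` gives > 40000 nM in this assay, also a limit.

Compound 3 therefore stands where every measured compound in this set stands: at the limit of this assay, with no numerical value to rank it against compound 1 or compound 2. All three share the feature described by the limit of > 40000 nM in this assay, at which 3 of the 3 values shown sit, so nothing among them distinguishes a stronger from a weaker inhibitor.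

Compound 4 `COc1ccc(/C=C/c2cc(=O)c3c(OC)cc(OC)cc3o2)cc1` is not yet measured. It differs from compound 3 in one place: methoxy in place of hydrogen on an aromatic carbon. Within the data shown here, no measured pair in this set shows what this change does, so the expectation for the step from compound 3 to compound 4 rests only on where compound 3 sits. Since every measured value is a limit, the step from compound 3 to compound 4 is expected to be none beyond the scatter, as expressed by a number no higher from compound 3 to compound 4 (the limit leaves the size open). Compound 4 is accordingly estimated at 40000 nM, within a range from 10000 nM to 120000 nM, with a strong chance that this assay again reports only a limit.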

Compound 4, half-maximal inhibitory concentration: > 40000 nM
Compound 4 ended at the assay's limit; the forecaster's own chance of this, stated with the estimate: 75%; the middle value sits exactly at the limit.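

The change from compound 3 to compound 4, phenyl to 4-methoxyphenyl, gives no readable step, because neither compound has a number to compare, only a limit: the limit of > 40000 nM in this assay, at which 4 of the 4 values shown sit.

The compounds shown leave open whether methoxy in place of hydrogen on an aromatic carbon changes activity at all, and how these four compounds rank against one another.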